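This account rests on a few compounds, and the source may have more. Where it says the series, first, only, none or still open, it means among the compounds named here.

Measured so far:

`O=C(NCc1ccc(CNS(=O)(=O)c2ccccc2)cc1)c1ccc(F)cc1`, compound 1, 40%
`COc1cccc(C(=O)NCc2ccc(CNS(=O)(=O)c3ccc(C)cc3)cc2)c1`, compound 2, 28%
`Cc1ccc(S(=O)(=O)NCc2ccc(CNC(=O)c3ccc(Cl)cc3)cc2)cc1`, compound 3, 50%

The three measured compounds share a common core and differ in the aryl group on the carbonyl carbon and in the sulfonyl aryl group. In a functional assay on the whole organism for inhibition, with Mus musculus as the target, with stated times of 30 min and 2 h, at a dose of 10 mg/kg by the intraperitoneal route (a lower number here means less inhibition, a higher number more inhibition at the dose given (going by the name of the read-out)), compound 1 gives 40%, the second highest of the three numbers. Its nearest neighbour is compound 3 with 50%, a gap that stays within the scatter, while compound 2 with 28% lies beyond the scatter below it.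

Compound 4 is `O=C(NCc1ccc(CNS(=O)(=O)c2ccccc2)cc1)c1ccncc1`, and it is not yet measured. It differs from compound 1 in one place: pyridin-4-yl in place of 4-fluorophenyl on a carbonyl carbon.

Among the compounds with values here, the only measured step that changes the aryl group on the carbonyl carbon is a number 22 percentage points higher from compound 2 to compound 3 (beyond the scatter), which shows that this position can move the read-out modestly. That step, however, also involves a different sulfonyl aryl group and neither of its two aryl groups is pyridin-4-yl, so it gives no direct guide to the present change. Within the data shown here, no measured pair shows what pyridin-4-yl does at this position.

With that, the expectation for compound 4 is a step of a number 10 percentage points lower from compound 1 to compound 4 (within the scatter) in this assay, which may fall within the scatter. Compound 4 is estimated at 30%, within a range from 10% to 50%.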

Compound 4, a percentage reported as inhibition, in the whole organism at one dose (the size of the read-out at that dose, not a potency): 40%
Beside the measured number, compound 4's estimate is 10 percentage points below it, within the range that was stated.
By their numbers in this assay, from the lowest: compound 2; then compounds 1, 4 and 3 (each within the scatter of the next).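

In this assay, the exchange gives no change at the digits printed from compound 1 to compound 4 (within the scatter) and so shows that, on this carbonyl carbon, pyridin-4-yl with its ring nitrogen and hydrogen-bond acceptor can stand in place of 4-fluorophenyl with no shift beyond the scatter. The earlier step of a number 22 percentage points higher from compound 2 to compound 3 (beyond the scatter) had shown only that this position can move the read-out, so the new pair adds that not every exchange of the ring here does so. Nothing at hand explains why these two rings read alike.

Still open, from the compounds shown here alone, is whether this position stays as undemanding for groups further removed from these aromatic rings, such as a cyclohexyl ring, a carboxylic acid or a longer alkyl chain on the same carbonyl carbon. Going by these compounds, it is also open whether pyridin-4-yl would read the same on the sulfonyl side of compound 3, and how far a single-dose percentage in the whole organism reflects a change in potency rather than only the size of the effect at that dose.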